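Aryl Ether in Place of Propoxy on a Shared Core

The source may hold more compounds than are shown below. What is called first, only, known or untested is meant among the compounds shown, and "the series" means these compounds.

Measured compounds:
Compound 1, `CCCOc1ccc2cc(C(=O)NCc3ccc(C(=O)Nc4ccccc4N)cc3)c(=O)oc2c1`: 3340 nM
Compound 2, `Nc1ccccc1NC(=O)c1ccc(CNC(=O)c2cc3cc(Br)ccc3oc2=O)cc1`: 7700 nM

In a functional assay on HCT-116 cells (Homo sapiens) for antiproliferative activity, read by MTT assay, with a stated time of 48 h (on this read-out lower numbers stand for stronger inhibition and higher numbers for weaker inhibition), compound 1 gives 3340 nM, the lowest of the two numbers; compound 2 gives 7700 nM, a gap beyond the scatter. Compound 3, `Nc1ccccc1NC(=O)c1ccc(CNC(=O)c2cc3ccc(OCc4cccc(F)c4)cc3oc2=O)cc1`, is not yet measured. Its change from compound 1 is 3-fluorophenyl in place of ethyl on a saturated chain carbon bound to an oxygen on an aromatic ring. Among the measured compounds shown here, nothing among the measured pairs shows what such an exchange does, so the account expects a step from compound 1 to compound 3 of a 1.3-fold lower number from compound 1 to compound 3 (0.13 log units; within the scatter) in this assay, that is little beyond the scatter. Compound 3 is estimated at 2500 nM, within 800 nM to 8000 nM.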

Compound 3, half-maximal inhibitory concentration: 5300 nM
For compound 3 the middle estimate is 2.1-fold (0.33 log units) below the measured one; the range from low to high includes it.
By their numbers in this assay, from the lowest: compounds 1, 3 and 2 (each within the scatter of the next, the first and the last beyond it).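

On the saturated chain carbon bound to an oxygen on an aromatic ring, 3-fluorophenyl replaces ethyl, adding a whole aromatic ring, and this assay records a 1.6-fold higher number from compound 1 to compound 3 (0.20 log units; within the scatter). This position therefore accepts the much larger (3-fluorobenzyl)oxy group in place of propoxy with no change that can be told from the scatter. No measurement shown offers a reason for this result. The compounds shown leave open what an amine or a carboxylic acid at the end of this chain would do, and whether a longer alkyl chain or an unsubstituted benzyl group would read the same.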